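Aniline substituent swap in the glutarimide imide series

The compounds below may be only part of what the source reports. "The series", "measured", "known", "first", "only" and "open" are said of these compounds alone.

Compound 2 `CC(C)(C)c1ccc(Nc2cccc3c2C(=O)N(C2CCC(=O)NC2=O)C3=O)cc1` holds the highest number of the three measured anilines in an assay on FRT-Jurkat cells for inhibition of nuclear factor NF-kappa-B complex (Homo sapiens), read by flow cytometry, with a stated time of 24 h, tested at 10 uM (a lower number here means less inhibition, a higher number more inhibition at the concentration tested (going by the name of the read-out)), where compound 2 gives 36%. Compound 1 `COc1ccc(Nc2ccc3c(c2)C(=O)N(C2CCC(=O)NC2=O)C3=O)cc1` lies nearest: in this assay compound 1 gives 29%, which sits within the scatter of compound 2, so no order between the two is claimed. Compound 3 `Cc1ccc(Nc2ccc3c(c2)C(=O)N(C2CCC(=O)NC2=O)C3=O)cc1` lies furthest, and in this assay compound 3 gives 5%. Among the compounds with values here, the only single-point step among the measured compounds is a number 24 percentage points lower from compound 1 to compound 3 (beyond the scatter), a swap of the group on the aniline ring that moved the number by a modest margin beyond the scatter.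

Compound 4 `CCc1ccc(Nc2cccc3c2C(=O)N(C2CCC(=O)NC2=O)C3=O)cc1` differs from compound 2 by ethyl in place of tert-butyl on an aromatic carbon. Within the data shown here, no measured step covers this particular exchange; the step from compound 1 to compound 3 shows only that a small exchange of the group on that ring can shift the read-out modestly, without telling the direction for tert-butyl to ethyl. The expectation is therefore a small downward move or none beyond the scatter, a step of a number 9 percentage points lower from compound 2 to compound 4 (within the scatter) from compound 2 to compound 4. Compound 4 is estimated at 27%, with a range from 8% to 46%.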

Compound 4, a percentage reported as inhibition, at one concentration (the size of the read-out at that concentration, not a potency): 17%
The estimate for compound 4 lay 10 percentage points above the measured number; the range from low to high includes it.
By their numbers in this assay, from the lowest: compound 3; then compound 4; then compounds 1 and 2 (each within the scatter of the next).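

Exchanging the 4-(tert-butyl)phenyl for the 4-ethylphenyl on the core of compound 2 gives a number 19 percentage points lower from compound 2 to compound 4 (beyond the scatter) in this assay, so the size of the read-out on this core depends on which alkyl group sits on the aniline ring, para to a large group. The earlier step, a number 24 percentage points lower from compound 1 to compound 3 (beyond the scatter), came from the other core and from a methoxy to methyl exchange, so it showed sensitivity to this substituent only there; the new step extends that sensitivity to a second core and to an exchange of one alkyl group for another, with the group going from four heavy atoms to two. Nothing available explains why the number falls with this exchange.

Open, going by these compounds, is how the read-out behaves with an isopropyl group or a longer chain such as n-butyl at this place on the core of compound 2, which would show whether the number follows the size of the alkyl group or is particular to tert-butyl. Also open, on these data alone, is what an amine or a carboxylic acid would do at the same place, and whether the tert-butyl to ethyl step holds on the core of compound 1.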